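The compounds below may be only part of what the source reports. "The series", "measured", "known", "first", "only" and "open" are said of these compounds alone.

Measured in a functional assay, read by spectrophotometry, with a stated time of 5 min; on this read-out higher numbers stand for weaker inhibition and lower numbers for stronger inhibition:
- Compound 1 `COc1cc(/C=C/C(=O)C(=Cc2ccc(OC)c(OC)c2)C(=O)/C=C/c2ccc(O)c(OC)c2)ccc1O`: 71000000 nM
- Compound 2 `CCOc1ccc(C=C(C(=O)/C=C/c2ccc(O)c(OC)c2)C(=O)/C=C/c2ccc(O)c(OC)c2)cc1OCC`: 73000000 nM
- Compound 3 `CCOc1cc(C=C(C(=O)/C=C/c2ccc(O)c(OCC)c2)C(=O)/C=C/c2ccc(O)c(OCC)c2)ccc1O`: 96700000 nM

In this assay, compound 3 lies within the usual scatter of both compound 1 and compound 2, so these three values cannot be put in any firm order. The next compound, compound 4 `CCOc1cc(/C=C/C(=O)C(=Cc2ccccc2)C(=O)/C=C/c2ccc(O)c(OCC)c2)ccc1O`, differs from compound 3 by one exchange: phenyl in place of 3-ethoxy-4-hydroxyphenyl on a double-bonded chain carbon bound to a double-bonded chain carbon. Phenyl replaces 3-ethoxy-4-hydroxyphenyl on a double-bonded chain carbon bound to a double-bonded chain carbon.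

Among the compounds with values here, only one measured step changes this same place: a 1.0-fold higher number from compound 1 to compound 2 (0.01 log units; within the scatter). That step, from 3,4-dimethoxyphenyl to 3,4-diethoxyphenyl, lies within the scatter. Within the data shown here, it is only a partial guide, since it swaps one substituted phenyl for another and no measured compound carries plain phenyl here. Compound 1 and compound 2 also lack 3-ethoxy-4-hydroxyphenyl at this place, yet they stay within the scatter of compound 3, although compound 3 differs from them elsewhere too.

On this thin evidence, no change beyond the scatter is expected in this assay, in either direction. The expected step is a 1.1-fold lower number from compound 3 to compound 4 (0.06 log units; within the scatter). The estimate for compound 4 is 85000000 nM, with an expected range from 35000000 nM to 200000000 nM.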

Compound 4, half-maximal inhibitory concentration: 91400000 nM
The estimate for compound 4 lay 1.1-fold (0.03 log units) below the measured number; measured number inside the range.
By their numbers in this assay, from the lowest: compounds 1, 2, 4 and 3 (each within the scatter of the next).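

Putting phenyl in place of 3-ethoxy-4-hydroxyphenyl on a double-bonded chain carbon bound to a double-bonded chain carbon gives, in this assay, a 1.1-fold lower number from compound 3 to compound 4 (0.02 log units; within the scatter). The earlier step only swapped one substituted phenyl for another, whereas this one leaves a bare ring, taking away the ethoxy and hydroxy groups with their hydrogen-bond donor and acceptors, and the read-out still stays within the scatter, so in this pair neither group is needed to keep the number where it is. No measurement shown here offers an explanation for this lack of change.

From the compounds shown here alone, what happens with a different kind of group at this place stays open: an amine, a carboxylic acid or a longer chain such as butoxy on the ring might or might not move the number beyond the scatter. Also open is whether the other 3-ethoxy-4-hydroxyphenyl groups that compound 4 still carries can be exchanged for phenyl just as freely, since the compounds shown include no such change.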